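The source may report more compounds than this note shows. Statements on the series, on what has been measured and on what is new or still open speak of the compounds shown alone.

Compound 1, `Fc1ccc(/C=N/c2sc3c(c2-c2nc4ccccc4s2)CCC3)cc1`: 302 ug/mL
Compound 2, `Fc1ccccc1/C=N/c1sc2c(c1-c1nc3ccccc3s1)CCC2`: 394 ug/mL

Both numbers come from an ADME assay on HepG2 cells (Homo sapiens) for cytotoxicity, read by MTT assay, with a stated time of 72 h (on this read-out lower numbers stand for higher toxicity in this test and higher numbers for lower toxicity in this test), which reports the concentration at which the liver-derived cells are killed. Compound 2 has the larger of the two numbers, but the step of a 1.3-fold higher number from compound 1 to compound 2 (0.12 log units; within the scatter) lies within the scatter, so compound 1 and compound 2 cannot be told apart on this evidence. Compound 3, `Clc1ccccc1/C=N/c1sc2c(c1-c1nc3ccccc3s1)CCC2`, has not yet been tested. It differs from compound 2 by chloro in place of fluoro on an aromatic carbon. Going by the values given here, only one measured step exists here, and it concerns moving the fluoro group around the ring rather than exchanging it; no measured pair swaps fluoro for chloro. That single step was within the scatter, and nothing else points to a change in this assay , so no shift beyond the scatter is expected from compound 2 to compound 3. Compound 3 is therefore estimated at 360 ug/mL, with a range from 180 ug/mL to 720 ug/mL. This estimate means an expected step of a 1.1-fold lower number from compound 2 to compound 3 (0.04 log units; within the scatter).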

Compound 3, half-maximal cytotoxic concentration: 180 ug/mL
For compound 3 the middle estimate is 2.0-fold (0.30 log units) above the measured one, within the range that was stated.
By their numbers in this assay, from the lowest: compounds 3, 1 and 2 (each within the scatter of the next, the first and the last beyond it).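

In this assay, going by these compounds alone, exchanging one halogen for another at this aromatic carbon, ortho to a large group, gives the first step to clear the scatter: a 2.2-fold lower number from compound 2 to compound 3 (0.34 log units; beyond the scatter) for chloro in place of fluoro, whereas the earlier step only moved fluoro around the ring. The other new step, a 1.7-fold lower number from compound 1 to compound 3 (0.22 log units; within the scatter) with 2-chlorophenyl in place of 4-fluorophenyl, stays within the scatter, so this pair cannot be told apart and the shift is seen only against the 2-fluorophenyl compound. Nothing available explains why this exchange lowers the number.

From the compounds shown here alone, whether a bromo or a methyl group on the same carbon would follow chloro remains open. So does whether a 4-chlorophenyl group, or an amine or a carboxylic acid on this ring, would shift the number at all.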